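Methylating the ring oxygen: from compound 2 to compound 3

The source may report more compounds than this note shows. Statements on the series, on what has been measured and on what is new or still open speak of the compounds shown alone.

Of the compounds shown here, two carry numbers so far. Compound 1 `CN(C)c1ccc(/C=N\NC(=S)NC2CCCCC2)cc1` and compound 2 `Oc1cccc(/C=N\NC(=S)NC2CCCCC2)c1` share a core and differ in the group on the aromatic ring. In a functional assay on MDA-MB-468 cells (Homo sapiens) for inhibition, read by WST assay, with a stated time of 48 h (a lower number here means a stronger inhibitor, a higher number a weaker inhibitor), compound 1 gives 280000 nM. In this assay compound 2 gives 32200 nM, the lowest of the two numbers; its nearest neighbour is compound 1, and that gap lies beyond the scatter. Within the data shown here, no measured pair differs in a single place, so no single-point step is available to calibrate the next change.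

Compound 3 `COc1cccc(/C=N\NC(=S)NC2CCCCC2)c1` awaits measurement in this assay. It differs from compound 2 by methyl in place of hydrogen on an oxygen on an aromatic ring. Nothing measured in the series speaks to a change of this kind, so the expectation rests on the value of compound 2 alone, 32200 nM. The step of a 1.6-fold higher number from compound 2 to compound 3 (0.19 log units; within the scatter) is expected to be small, at most just beyond the scatter, with a slight lean toward a higher number and wide uncertainty either way. Compound 3 is estimated at 50000 nM, with a range from 12000 nM to 200000 nM.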

Compound 3, half-maximal inhibitory concentration: 46700 nM
Estimate against measurement, compound 3: 1.1-fold (0.03 log units) above; the measured number falls inside the stated range.
By their numbers in this assay, from the lowest: compounds 2 and 3 (each within the scatter of the next); then compound 1.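

In this assay, the series now has its first step that can be read at a single place, a 1.5-fold higher number from compound 2 to compound 3 (0.16 log units; within the scatter), so hydroxy and methoxy on this aromatic ring cannot be told apart here. The hydrogen on the oxygen can therefore give way to methyl with no step beyond the scatter, which the earlier pair, differing in more than one place, could not show, although this is a single pair and sets no pattern for other changes at this position. No independent measurement accompanies this result to explain why the step stays within the scatter.

The compounds shown leave open how far this tolerance extends on the oxygen, for instance whether an ethyl group or a longer chain would also stay within the scatter of compound 2. They also leave open what happens when the oxygen itself is replaced on the aromatic ring, for example by an amine or a carboxylic acid, and whether any such change would move the number beyond the scatter in either direction.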